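Simplifying the amide aryl group ahead of measuring compound 4

A few compounds are considered here, and "the series" means these few. Any claim that something is new, unique, unknown or untested is made for them only; others in the source may bear on it.

Measured so far:
Compound 1, `COc1cc(-c2nn(-c3cccc(NC(=O)Nc4ccc(Cl)c(Cl)c4)c3)cc2-c2ccncc2)ccc1Cl`: in a functional assay on RXF 393 cells (Homo sapiens) for inhibition, read by sulforhodamine B assay, with a stated time of 48 h (on this read-out lower numbers stand for higher toxicity in this test and higher numbers for lower toxicity in this test), compound 1 gives > 50000 nM, which is a limit of the assay.
Compound 2, `COc1cc(-c2nn(-c3cccc(NC(=O)Nc4cccc(C(F)(F)F)c4)c3)cc2-c2ccncc2)ccc1Cl`: in this assay compound 2 gives 4830 nM.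
Compound 3, `COc1cc(-c2nn(-c3cccc(NC(=O)c4ccc(Cl)c(C(F)(F)F)c4)c3)cc2-c2ccncc2)ccc1Cl`: in this assay compound 3 gives > 32500 nM, which is a limit of the assay.

Compound 3 therefore stands at the limit of > 32500 nM in this assay, at which 1 of the 3 values shown sits, and carries no number of its own. Of the steps that end at compound 3, an at least 6.7-fold higher number from compound 2 to compound 3 (0.82 log units; beyond the scatter). The other one, a step that the two limits leave unreadable from compound 1 to compound 3; both of its ends are limits.

Compound 4, `COc1cc(-c2nn(-c3cccc(NC(=O)c4ccccc4)c3)cc2-c2ccncc2)ccc1Cl`, has not been measured in this assay. It differs from compound 3 by phenyl in place of 4-chloro-3-(trifluoromethyl)phenyl on a carbonyl carbon. Going by the values given here, no measured step changes the amide aryl group alone; the single aryl exchange measured, an at least 10-fold lower number from compound 1 to compound 2 (1.01 log units; beyond the scatter), sits among the urea compounds and concerns a different pair of groups. The step nearest in kind, an at least 6.7-fold higher number from compound 2 to compound 3 (0.82 log units; beyond the scatter), ends at a limit, so the direction of the change is not readable from the present compounds. Compound 4 is expected to remain near the limit, with a wide range allowed. In this assay compound 4 is expected to give 30000 nM, between 7000 nM and 60000 nM. The step this estimate means is an at least 1.0-fold lower number from compound 3 to compound 4 (0.03 log units; that floor lies within the scatter), expected rather than known.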

Compound 4, concentration lethal to 50% of the cells: > 100000 nM
Compound 4 ended at the assay's limit; the forecaster's own chance of this, stated with the estimate: 55%; at least 3.3-fold (0.52 log units) between middle value and limit.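

Phenyl in place of 4-chloro-3-(trifluoromethyl)phenyl on a carbonyl carbon gives a second amide without a number of its own, and the steps from compound 3 and from compound 1 to compound 4 cannot be read. Going by these compounds alone, the one readable step, an at least 20-fold higher number from compound 2 to compound 4 (1.31 log units; beyond the scatter), is large, but it exchanges the whole (3-(trifluoromethyl)phenyl)amino group for phenyl and does not isolate the aryl group. Both aryl groups shown on the amide carbonyl now end at limits, while among the ureas compound 2 has a measured value and compound 1 goes against any simple split between amides and ureas, ending at a limit itself; for compound 4 the result is a limit of the assay: the limit of > 100000 nM in this assay, at which 1 of the 4 values shown sits.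

From the compounds shown here alone, whether removing the chlorine and the trifluoromethyl group moves the value at all stays open, since neither compound 3 nor compound 4 has a number to compare. Also open, going by these compounds, is how an amide with an amine or a carboxylic acid on the phenyl ring, or with a longer chain in place of the phenyl, would read in this assay.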